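The compounds below may be only part of what the source reports. "The series", "measured", "known", "first", "only" and "open" are said of these compounds alone.

Measured so far in a functional assay on MDA-MB-231 cells (Homo sapiens) for antiproliferative activity, read by MTT assay, with a stated time of 24 h; a higher number here means a weaker inhibitor, a lower number a stronger inhibitor:
- compound 1 `COC(=O)c1scc(-c2ccc(NC(=O)c3ccc4ccccc4c3)cc2)c1OC`: 5250 nM
- compound 2 `COC(=O)c1scc(-c2ccc(NC(=O)c3cccc(C(F)(F)F)c3)cc2)c1OC`: 24600 nM
- compound 3 `COC(=O)c1scc(-c2ccc(NC(=O)c3ccc(C#N)nc3)cc2)c1OC`: 28500 nM

Compound 3 cannot be separated from compound 2 on these numbers: the step of a 1.2-fold higher number from compound 2 to compound 3 (0.06 log units; within the scatter) lies within the scatter. Against compound 1, the step of a 5.4-fold higher number from compound 1 to compound 3 (0.73 log units; beyond the scatter) lies beyond the scatter and is modest.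

Compound 4 `COC(=O)c1scc(-c2ccc(NC(=O)c3ccc(OC)nc3)cc2)c1OC` follows from compound 3 by one change: methoxy in place of cyano on an aromatic carbon. In words, methoxy stands in place of cyano on an aromatic carbon, next to the ring nitrogen and para to a large group, turning 6-cyanopyridin-3-yl into 6-methoxypyridin-3-yl.

Going by the values given here, no measured step tests this exchange directly. The closest guide is the exchange of the whole group on the carbonyl carbon, a 1.2-fold higher number from compound 2 to compound 3 (0.06 log units; within the scatter), which stayed within the scatter. The larger steps, a 4.7-fold higher number from compound 1 to compound 2 (0.67 log units; beyond the scatter) and a 5.4-fold higher number from compound 1 to compound 3 (0.73 log units; beyond the scatter), both remove naphthalen-2-yl, and that group is absent from compound 3 and compound 4 alike. In this assay, therefore, no shift beyond the scatter is expected in either direction. The expected step is a 1.3-fold lower number from compound 3 to compound 4 (0.11 log units; within the scatter). For compound 4 the estimated value is 22000 nM, with an expected range of 9000 nM to 50000 nM.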

Compound 4, half-maximal inhibitory concentration: 15300 nM
Beside the measured number, compound 4's estimate is 1.4-fold (0.16 log units) above it; the measured number falls inside the stated range.
By their numbers in this assay, from the lowest: compound 1; then compounds 4, 2 and 3 (each within the scatter of the next).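

In this assay, going by these compounds alone, the step of a 1.9-fold lower number from compound 3 to compound 4 (0.27 log units; within the scatter) is the first direct test of a change on the aromatic carbon next to the ring nitrogen and para to a large group, and it shows that cyano and methoxy cannot be separated at this position. Within the data shown here, the comparison with the benzamide side is likewise unresolved: the step of a 1.6-fold lower number from compound 2 to compound 4 (0.21 log units; within the scatter) places 6-methoxypyridin-3-yl with 3-(trifluoromethyl)phenyl, so three different groups on the carbonyl carbon now share one band of values, with no compound among 2, 3 and 4 going against this. Naphthalen-2-yl stays apart, as the step of a 2.9-fold higher number from compound 1 to compound 4 (0.46 log units; beyond the scatter) gives a third replacement of that group that lies beyond the scatter, although this step is modest and is shown only for these groups.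

Still open, on these data alone, is whether an amine, a carboxylic acid or a longer alkoxy chain such as butoxy on the same carbon would leave the number within this band or move it toward that of compound 1. The series offers no measurement that explains any of these steps.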